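Swapping One Five-Membered Ring for Another in Compound 4

The compounds below may be only part of what the source reports. "The series", "measured", "known", "first", "only" and "open" are said of these compounds alone.

Among the three compounds measured so far, compound 3 `Cn1ccc(-c2ccccc2NCC2=NCCN2)n1` sits in the middle. In a functional assay with Alpha-1D adrenergic receptor (Homo sapiens) as the target, read by calcium flux (on this read-out higher numbers stand for larger maximal responses and lower numbers for smaller maximal responses), compound 3 gives 29%. Its closest neighbour is compound 1 `Cn1cccc1-c1ccccc1NCC1=NCCN1`, which in this assay gives 32%; the two differ only a number 3 percentage points lower from compound 1 to compound 3 (within the scatter). The outlier is compound 2 `Cn1cc(-c2ccccc2NCC2=NCCN2)cn1`, which gives 0%, so that the change a number 29 percentage points higher from compound 2 to compound 3 (beyond the scatter).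

Compound 4 `Cn1ccnc1-c1ccccc1NCC1=NCCN1` has not yet been measured. It differs from compound 3 in one place: 1-methyl-1H-imidazol-2-yl in place of 1-methyl-1H-pyrazol-3-yl on an aromatic carbon.

Going by the values given here, the steps that bear on this are the two that trade one five-membered ring for another on the same aromatic carbon. The move from a 1-methyl-1H-pyrrol-2-yl to a 1-methyl-1H-pyrazol-3-yl in compound 1 to compound 3 lay within the scatter, while the move from a 1-methyl-1H-pyrazol-4-yl to a 1-methyl-1H-pyrazol-3-yl in compound 2 to compound 3 was modest. Two of three rings tried give a similar maximal response and one gives none, so the safest expectation for compound 4 is a small step, estimated as a number 4 percentage points lower from compound 3 to compound 4 (within the scatter). Compound 4 is therefore expected to give about 25%, within a range from 5% to 45%.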

Compound 4, largest response reached (reported as maximal response), in percent of the reference or control that the assay uses: 92%
Estimate against measurement, compound 4: 67 percentage points below, and the stated range ends below it.
By their numbers in this assay, from the lowest: compound 2; then compounds 3 and 1 (each within the scatter of the next); then compound 4.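

In this assay the 1-methyl-1H-imidazol-2-yl ring on this aromatic carbon brings a number 63 percentage points higher from compound 3 to compound 4 (beyond the scatter) and a number 60 percentage points higher from compound 1 to compound 4 (beyond the scatter) and a number 92 percentage points higher from compound 2 to compound 4 (beyond the scatter) and so stands apart from all three other rings. Going by these compounds alone, the modest responses of the earlier compounds were therefore a feature of the rings they carried and not a limit set by this position on the shared core. The rings of compound 3 and compound 4 match in heavy atoms, hydrogen-bond donors, hydrogen-bond acceptors and net charge and differ only in how their atoms are joined, yet nothing available here says why that difference matters so much.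

The four compounds leave open whether the high response needs the methyl group on the imidazole, which a plain 1H-imidazol-2-yl ring or a 1-ethyl-1H-imidazol-2-yl ring would test. They also leave open whether other rings on the same aromatic carbon, such as a thiazol-2-yl or a six-membered pyridin-2-yl, would behave like compound 4 or like the other three compounds.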